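Nitro for Cyano on Two Related Anilide Cores

The source may report more compounds than this note shows. Statements on the series, on what has been measured and on what is new or still open speak of the compounds shown alone.

In a functional assay on VCaP cells (Homo sapiens) for antiproliferative activity, read by propidium iodide staining, with a stated time of 96 h (on this read-out lower numbers stand for stronger inhibition and higher numbers for weaker inhibition), the measured compounds are:
compound 1 `CC(O)(CSc1cccc(S(F)(F)(F)(F)F)c1)C(=O)Nc1ccc(C#N)c(C(F)(F)F)c1`, 31700 nM
compound 2 `CC(O)(CSc1cccc(S(F)(F)(F)(F)F)c1)C(=O)Nc1ccc([N+](=O)[O-])c(C(F)(F)F)c1`, 9800 nM
compound 3 `CC(O)(COc1ccc(S(F)(F)(F)(F)F)cc1)C(=O)Nc1ccc(C#N)cc1C(F)(F)F`, 25500 nM

Compound 2 differs from compound 1 by nitro in place of cyano on an aromatic carbon, and this change gave a 3.2-fold lower number from compound 1 to compound 2 (0.51 log units; beyond the scatter) in this assay. Compound 3 and compound 1 share the same change in prospect but their cores are not the same; the difference between the two cores is not broken down here. Compound 4 `CC(O)(COc1ccc(S(F)(F)(F)(F)F)cc1)C(=O)Nc1ccc([N+](=O)[O-])cc1C(F)(F)F` differs from compound 3 by nitro in place of cyano on an aromatic carbon. This is the same kind of change as from compound 1 to compound 2, though the place differs: in compound 4 the new group sits meta to a trifluoromethyl group, whereas in compound 2 it sits ortho to one. Resting on the step from compound 1 to compound 2 a 3.2-fold lower number from compound 1 to compound 2 (0.51 log units; beyond the scatter), a step of similar direction is expected here, a 2.8-fold lower number from compound 3 to compound 4 (0.45 log units; beyond the scatter), while the different placing adds uncertainty. The estimated value for compound 4 in this assay is 9000 nM, expected between 3500 nM and 25000 nM.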

Compound 4, half-maximal inhibitory concentration: 26100 nM
Beside the measured number, compound 4's estimate is 2.9-fold (0.46 log units) below it; measured number outside the range, above it.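

In this assay, nitro in place of cyano on the core of compound 3 gave a 1.0-fold higher number from compound 3 to compound 4 (0.01 log units; within the scatter), so here the two values cannot be told apart. The same change therefore did not carry over with the same size from the core of compound 1 to the core of compound 3: the same change on two cores in this assay, a 3.2-fold lower number (0.51 log units; beyond the scatter) from compound 1 to compound 2 and a 1.0-fold higher number (0.01 log units; within the scatter) from compound 3 to compound 4, 3.3-fold (0.52 log units) apart, beyond the scatter of two such steps. The two cores differ in more than one place, so these two pairs do not show which difference matters, or what the change would do on any other core.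

The compounds shown leave open how the nitro step would read on a third core. Also open, from the compounds shown here alone, is how an amine or a carboxylic acid on that same aromatic carbon would compare in this assay.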